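A few compounds are considered here, and "the series" means these few. Any claim that something is new, unique, unknown or untested is made for them only; others in the source may bear on it.

Series notes, two measured compounds and one open position.

Compound 1 `CCC(=O)Nc1sc2c(c1C#N)CCCC2` carries only hydrogen at the end of the propanamide chain; in a functional assay on RKE cells for antagonist activity at Vasoactive intestinal polypeptide receptor 1 (Rattus norvegicus), read by HTRF and cAMP accumulation, with stated times of 10 min and 30 min (on this read-out lower numbers stand for stronger inhibition and higher numbers for weaker inhibition), compound 1 gives 12000 nM. Compound 2 `Cc1cccc(CCC(=O)Nc2sc3c(c2C#N)CCCC3)c1` adds a 3-methylphenyl to that chain; in this assay compound 2 gives 750 nM. For the measured compounds named here, the only step measured so far, a 16-fold lower number from compound 1 to compound 2 (1.20 log units; beyond the scatter), comes from putting 3-methylphenyl in place of hydrogen on a saturated chain carbon, two bonds along the chain from a carbonyl carbon. On the numbers shown, compound 2 stands lowest of the two, with compound 1 as its only neighbour.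

Compound 3 `COc1cccc(CCC(=O)Nc2sc3c(c2C#N)CCCC3)c1` differs from compound 2 by methoxy in place of methyl on an aromatic carbon; cut one bond further out, the change reads 3-methylphenyl to 3-methoxyphenyl. Going by the values given here, the one measured step concerns the presence of the aryl group as a whole, not a swap of one small substituent on it, so it bears on compound 3 only in showing that the aryl-bearing chain is where the low numbers sit. Among the compounds with values here, no measured step covers methyl against methoxy here. The expected step of a 1.1-fold higher number from compound 2 to compound 3 (0.03 log units; within the scatter) is therefore set within the scatter, with no direction. For compound 3 in this assay the estimate is 800 nM, in the range 300 nM to 2200 nM.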

Compound 3, half-maximal inhibitory concentration: 610 nM
Beside the measured number, compound 3's estimate is 1.3-fold (0.12 log units) above it, and the stated range covers the measured number.
By their numbers in this assay, from the lowest: compounds 3 and 2 (each within the scatter of the next); then compound 1.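

On the aromatic carbon meta to a large group, methoxy in place of methyl gives a 1.2-fold lower number from compound 2 to compound 3 (0.09 log units; within the scatter) in this assay, so the added oxygen and its one hydrogen-bond acceptor leave the number within the scatter at this position. Set against compound 1, the second aryl group gives a 20-fold lower number from compound 1 to compound 3 (1.29 log units; beyond the scatter), so the large drop on placing an aryl group on the propanamide chain now holds for both 3-methylphenyl and 3-methoxyphenyl rather than resting on a single example. No outside information bears on why these two substituents read alike, and the numbers alone cannot settle that question.

On these data alone, with only methyl and methoxy in view, it remains open whether a different kind of group at this ring position, such as an amine or a carboxylic acid, would stay in the same range as compound 2 and compound 3. Also open, as far as these compounds go, are whether methoxy on another aromatic carbon of the ring would read the same, and how a longer chain between the carbonyl and the aryl group would read.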